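A few compounds are considered here, and "the series" means these few. Any claim that something is new, unique, unknown or untested is made for them only; others in the source may bear on it.

Measured in a functional assay on MCF7 cells (Homo sapiens) for antiproliferative activity, with a stated time of 5 days; on this read-out higher numbers stand for weaker inhibition and lower numbers for stronger inhibition:
- compound 1 `CCCCc1ccc2[nH]c(-c3ccc(C(F)(F)F)cc3)c(/C=N/NC(=O)c3ccc(Cl)cc3)c2c1`: 1060 nM
- compound 2 `CCCCc1ccc2[nH]c(-c3ccc(OC)cc3)c(/C=N/NC(=O)c3ccc([N+](=O)[O-])cc3)c2c1`: 312 nM

Compound 2 (312 nM) holds the lower of the two numbers, and its gap to compound 1 lies beyond the scatter. Compound 3 `CCCCc1ccc2[nH]c(-c3ccc(C(F)(F)F)cc3)c(/C=N/NC(=O)c3ccc([N+](=O)[O-])cc3)c2c1` comes from compound 2 by a single change, trifluoromethyl in place of methoxy on an aromatic carbon, para to a large group (trifluoromethyl in place of methoxy on an aromatic carbon). Among the measured compounds shown here, no single-change step has been measured, so the expectation rests on the two values alone. Compound 1 (1060 nM) carries the same trifluoromethyl group as compound 3, but the two also differ elsewhere. A small step towards weaker inhibition is therefore expected, and it may not clear the scatter: the estimated step is a 1.9-fold higher number from compound 2 to compound 3 (0.28 log units; within the scatter) in this assay on this basis. Compound 3 is estimated at 600 nM (expected range 220 nM to 1500 nM).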

Compound 3, half-maximal inhibitory concentration: 6340 nM
Compound 3: middle estimate off by 11-fold (1.02 log units), on the low side; measured number above the stated range.
By their numbers in this assay, from the lowest: compound 2; then compound 1; then compound 3.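

In this assay the place held by 4-methoxyphenyl is far from indifferent: with nitro kept, the change to 4-(trifluoromethyl)phenyl gives a 20-fold higher number from compound 2 to compound 3 (1.31 log units; beyond the scatter), a large step towards weaker inhibition. The other place also counts, since with trifluoromethyl kept, nitro in place of chloro on an aromatic carbon gives a 6.0-fold higher number from compound 1 to compound 3 (0.78 log units; beyond the scatter), a modest step in the same direction, so nitro offers no general gain in this series. No measurement available here bears on the reason for either step.

On these data alone, whether methoxy is specifically favoured at this place remains open, and a hydroxyl, a dimethylamino group or plain hydrogen there would test this. As far as these compounds go, it is also open whether the chloro-to-nitro step keeps its direction and size when methoxy replaces trifluoromethyl.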